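This account rests on a few compounds, and the source may have more. Where it says the series, first, only, none or still open, it means among the compounds named here.

Measured compounds:
- compound 1, `COc1ccccc1/C=C(/SCc1ccc(Cl)c(Cl)c1)C(=O)c1ccc(Cl)cc1`, in a functional assay on DU-145 cells (Homo sapiens) for inhibition, read by trypan blue exclusion, with a stated time of 96 h (a higher number here means a weaker inhibitor of growth, a lower number a stronger inhibitor of growth), gives 10000 nM
- compound 2, `COc1ccccc1/C=C(/SCc1ccc(Cl)cc1)C(=O)c1ccc(Cl)cc1`, gives 1000 nM
- compound 3, `COc1ccccc1/C=C(/Sc1ccc(C)cc1)C(=O)c1ccc(Cl)cc1`, gives 25000 nM

Compound 2 gives the lowest number of the three: the step of a 10-fold lower number from compound 1 to compound 2 (1.00 log units; beyond the scatter) and the step of a 25-fold higher number from compound 2 to compound 3 (1.40 log units; beyond the scatter) both lie beyond the scatter, so compound 2 is the strongest growth inhibitor measured here. Compound 4, `COc1ccc(/C=C(/SCc2ccc(Cl)cc2)C(=O)c2ccc(Cl)cc2)cc1`, keeps the sulfur-bound group of compound 2 and differs only in the methoxyphenyl: 4-methoxyphenyl in place of 2-methoxyphenyl on a double-bonded chain carbon bound to a double-bonded chain carbon. All three measured steps change the group on sulfur, so none bears directly on this change, and there is no basis for expecting a step beyond the scatter in either direction. For compound 4 the expected value is 1500 nM (range 500 nM to 5000 nM), an estimated step of a 1.5-fold higher number from compound 2 to compound 4 (0.18 log units; within the scatter).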

Compound 4, concentration for 50% growth inhibition: 10000 nM
For compound 4 the middle estimate is 6.7-fold (0.82 log units) below the measured one; measured number outside the range, above it.
By their numbers in this assay, from the lowest: compound 2; then compounds 1 and 4 (each within the scatter of the next); then compound 3.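

Where the methoxy group sits on the phenyl ring matters: the two compounds have the same atoms, yet 4-methoxyphenyl in place of 2-methoxyphenyl gives a 10-fold higher number from compound 2 to compound 4 (1.00 log units; beyond the scatter) in this assay. Among the compounds shown here, the earlier steps changed only the group on sulfur, so this is the first sign that the methoxyphenyl also influences growth inhibition. Nothing available explains this difference.

On these data alone, it remains open whether the same change would matter with another group on sulfur, such as 3,4-dichlorobenzyl. How an amine or a longer ether chain in place of the methoxy group would behave is also unknown.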